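The compounds below may be only part of what the source reports. "The series", "measured", "known", "first", "only" and "open" are said of these compounds alone.

Compound 1 `O=C(/C=C/c1cn(-c2ccccc2)nc1-c1cccnc1)c1ccsc1`: 500 nM
Compound 2 `O=C(/C=C/c1cn(-c2ccccc2)nc1-c1cccnc1)c1ccccn1`: 4200 nM
Compound 3 `COc1ccc(C(=O)/C=C/c2cn(-c3ccccc3)nc2-c2cccnc2)cc1OC`: 1700 nM

These three compounds share one core and differ only in the group attached to the carbonyl carbon. In a functional assay on MCF7 cells (Homo sapiens) for inhibition, read by sulforhodamine B assay, with a stated time of 72 h (on this read-out lower numbers stand for stronger inhibition and higher numbers for weaker inhibition), compound 1 gives the lowest number of the three; the nearest is a 3.4-fold higher number from compound 1 to compound 3 (0.53 log units; beyond the scatter) and the furthest is an 8.4-fold higher number from compound 1 to compound 2 (0.92 log units; beyond the scatter). Both replacements of thiophen-3-yl that have been measured so far therefore led to higher numbers, that is, weaker inhibition.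

Compound 4 `COc1ccc(C(=O)/C=C/c2cn(-c3ccccc3)nc2-c2cccnc2)c(OC)c1` has not yet been measured. Compared with compound 1 it carries 2,4-dimethoxyphenyl in place of thiophen-3-yl on a carbonyl carbon. Going by the values given here, the closest measured step is the one from compound 1 to compound 3, where a dimethoxyphenyl group with its two methoxy groups placed differently entered at the same carbonyl carbon and gave a modest rise, beyond the scatter. The step to the pyridin-2-yl compound points the same way but is larger. Since compound 4 differs from compound 3 only in where the methoxy groups sit, a modest rise of about the same size as a 3.4-fold higher number from compound 1 to compound 3 (0.53 log units; beyond the scatter) is expected, giving a 3.0-fold higher number from compound 1 to compound 4 (0.48 log units; beyond the scatter). For compound 4 the estimate in this assay is 1500 nM, with a likely range from 600 nM to 4000 nM.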

Compound 4, half-maximal inhibitory concentration: 2300 nM
Beside the measured number, compound 4's estimate is 1.5-fold (0.19 log units) below it, and the stated range covers the measured number.
By their numbers in this assay, from the lowest: compound 1; then compounds 3, 4 and 2 (each within the scatter of the next, the first and the last beyond it).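

Changing the dimethoxyphenyl pattern at this carbonyl carbon makes no clear difference in this assay: the step is a 1.4-fold higher number from compound 3 to compound 4 (0.13 log units; within the scatter), so the two dimethoxyphenyl groups cannot be told apart here. The result also adds a second dimethoxyphenyl arrangement to the comparison with thiophen-3-yl, with a 4.6-fold higher number from compound 1 to compound 4 (0.66 log units; beyond the scatter), so all three replacements shown give weaker inhibition than compound 1, and none goes against this pattern among these four compounds. The gap to the pyridin-2-yl group is no longer clear with this arrangement: the step is a 1.8-fold lower number from compound 2 to compound 4 (0.26 log units; within the scatter), so this dimethoxyphenyl group and pyridin-2-yl cannot be separated, even though the step between compound 2 and compound 3 is beyond the scatter.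

The data shown offer no measured explanation for any of these differences. From the compounds shown here alone, it remains open whether the lower number of compound 1 is specific to thiophen-3-yl or would also appear with a closely related ring such as furan-3-yl or thiophen-2-yl, with an unsubstituted phenyl, or with a phenyl carrying a single methoxy group or an amine.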